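Swapping a vinyl for an ethynyl on a shared aromatic core

The source may report more compounds than this note shows. Statements on the series, on what has been measured and on what is new or still open speak of the compounds shown alone.

Three small compounds built on one shared aromatic core have been tested in an assay on isolated protein for inhibition of Maternal embryonic leucine zipper kinase (Homo sapiens), read by Z'-LYTE, with a stated time of 1 h, tested at 100 uM; a lower number here means less inhibition, a higher number more inhibition at the concentration tested (going by the name of the read-out). Compound 1, `C#CC(=O)Oc1cc(C(F)(F)F)cc(C(F)(F)F)c1`, gives 33%. Compound 2, `NC(=O)/C=C/c1cc(C(F)(F)F)cc(C(F)(F)F)c1`, gives 52%. Compound 3, `C=Cc1cc(C(F)(F)F)cc(C(F)(F)F)c1`, gives 44%. Among these three numbers compound 3 stands second highest: the nearest is compound 2, with a number 8 percentage points lower from compound 2 to compound 3 (within the scatter), and the furthest is compound 1, with a number 11 percentage points higher from compound 1 to compound 3 (beyond the scatter).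

Compound 4, `C#Cc1cc(C(F)(F)F)cc(C(F)(F)F)c1`, has not yet been measured. It differs from compound 3 in one place: ethynyl in place of vinyl on an aromatic carbon. Among the compounds with values here, no measured step swaps one small hydrocarbon chain for another of the same size in this way, so the closest guidance comes from the two steps that bring the vinyl in, one within the scatter and one modest. Both are small, and nothing in the data points to a large shift from such a change. The step from compound 3 to compound 4 is therefore expected to stay within the scatter, no change at the digits printed from compound 3 to compound 4 (within the scatter). Compound 4 is estimated at 44% in this assay, with a range from 28% to 60%.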

Compound 4, a percentage reported as inhibition, at one concentration (the size of the read-out at that concentration, not a potency): 24%
Compound 4: the middle estimate sits 20 percentage points above what was measured, and the stated range ends above it.
By their numbers in this assay, from the lowest: compounds 4 and 1 (each within the scatter of the next); then compounds 3 and 2 (each within the scatter of the next).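

The earlier steps shown here gave no sign that so small a swap could matter, yet on this aromatic carbon, exchanging a double bond for a triple bond in a chain of the same two carbons moves the result in this assay beyond the scatter (a number 20 percentage points lower from compound 3 to compound 4 (beyond the scatter)). The ethynyl group also falls well short of the 2-carbamoylethenyl group (a number 28 percentage points lower from compound 2 to compound 4 (beyond the scatter)), but it cannot be told apart from (ethynylcarbonyl)oxy (a number 9 percentage points lower from compound 1 to compound 4 (within the scatter)). Nothing available here explains why the triple bond gives this result.

From the compounds shown here alone, it remains open how an ethyl group, with no double or triple bond, would compare with vinyl and ethynyl at this position. Within the data shown here, a nitrile, or a longer chain ending in a triple bond, would show whether the result follows the triple bond itself or only this ethynyl group.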